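A larger side arm on a series without measurable activity

The source may report more compounds than this note shows. Statements on the series, on what has been measured and on what is new or still open speak of the compounds shown alone.

Compound 3, with structure `CC(C)(N)CCCN(C[C@H]1Cc2ccccc2CN1)[C@H]1CCCc2cccnc21`, belongs to a small set of three related compounds tested in a functional assay on cells for agonist activity at C-X-C chemokine receptor type 4 (Homo sapiens), read by fluorescence and calcium flux, with a stated time of 90 s; on this read-out higher numbers stand for an effect only at larger amounts of compound and lower numbers for an effect already at smaller amounts. In this assay compound 3 gives only a limit of the assay, > 30000 nM, and no number. Compound 1, with structure `c1ccc2c(c1)CN[C@@H](CN(CCCCNCC1CCCCC1)[C@H]1CCCc3cccnc31)C2`, gives in this assay likewise only the limit > 30000 nM. Compound 2, with structure `c1ccc2c(c1)CN[C@@H](CN(CCCCNCC1CCNCC1)[C@H]1CCCc3cccnc31)C2`, gives in this assay only the limit > 30000 nM as well. The three therefore cannot be told apart, since all sit at the limit of > 30000 nM in this assay, at which 3 of the 3 values shown sit. Accordingly the step that the two limits leave unreadable from compound 1 to compound 2 is unreadable, and the same holds for a step that the two limits leave unreadable from compound 1 to compound 3 and for a step that the two limits leave unreadable from compound 2 to compound 3.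

Compound 4, with structure `CC(C)(CCN(C[C@H]1Cc2ccccc2CN1)[C@H]1CCCc2cccnc21)CNC1CCOCC1`, differs from compound 3 in one place: a group of 11 heavy atoms (9 carbon, 1 nitrogen, 1 oxygen; one six-membered non-aromatic ring with 1 hetero atom) in place of a group of 5 heavy atoms (4 carbon, 1 nitrogen; no ring), on a saturated chain carbon, two bonds along the chain from an amine nitrogen. No measured step bears readably on this change, so the shown data give no direction for it and no size beyond the scatter can be claimed in either direction. With every related compound at the limit, compound 4 is expected to behave the same way, and its value in this assay is estimated at 30000 nM, within a range from 10000 nM to 100000 nM. The estimated step of a number no higher from compound 3 to compound 4 (the limit leaves the size open) is thus expected to show no change that the assay could resolve.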

Compound 4, half-maximal effective concentration: > 30000 nM
Compound 4 ended at the assay's limit; the forecaster's own chance of this, stated with the estimate: 75%; the middle value sits exactly at the limit.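

In this assay compound 4 gives > 30000 nM, which is a limit of the assay and not a number. No step between compound 4 and compound 1, compound 2 or compound 3 can therefore be read, as all four stay at the same limit: the limit of > 30000 nM in this assay, at which 4 of the 4 values shown sit.

The compounds shown leave open whether any side arm on the shared core gives a measurable effect in this assay.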